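This account rests on a few compounds, and the source may have more. Where it says the series, first, only, none or still open, it means among the compounds named here.

Compound 1 `COc1ccc(CCCCCCCCOc2ccc(C[S+]([O-])c3cccc(C(=O)O)c3)nc2/C=C/C(=O)O)cc1` and compound 2 `COc1ccc(CCCCCCCCOc2ccc(C[S+]([O-])Cc3cccc(C(=O)O)c3)nc2/C=C/C(=O)O)cc1` share one core and differ only at the sulfur-bearing arm. In a functional assay on the whole organism with Homo sapiens as the target (a lower number here means a stronger inhibitor, a higher number a weaker inhibitor), compound 1 gives 3200 nM, and in this assay compound 2 gives 2600 nM. The gap a 1.2-fold lower number from compound 1 to compound 2 (0.09 log units; within the scatter) is small; compound 2 has the lower of the two numbers, but the two values cannot be told apart. Compound 3 `COc1ccc(CCCCCCCCOc2ccc(CSCc3ccc(C(=O)O)cc3)nc2/C=C/C(=O)O)cc1` takes the next step: a group of 11 heavy atoms (8 carbon, 2 oxygen, 1 sulfur; one six-membered aromatic ring of carbon only) in place of a group of 12 heavy atoms (8 carbon, 3 oxygen, 1 sulfur; one six-membered aromatic ring of carbon only), on a saturated chain carbon bound to an aromatic carbon. Among the measured compounds shown here, only the step from compound 1 to compound 2 touches this arm, and it was within the scatter, so the single precedent points to little change; the present change, however, removes the oxygen from the sulfur and moves the carboxylic acid on the ring, which no measured step covers. Compound 3 is therefore expected at 2500 nM, within 800 nM to 8000 nM. The expected step is a 1.0-fold lower number from compound 2 to compound 3 (0.02 log units; within the scatter).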

Compound 3, half-maximal inhibitory concentration: 426 nM
Compound 3: middle estimate off by 5.9-fold (0.77 log units), on the high side; measured number below the stated range.
By their numbers in this assay, from the lowest: compound 3; then compounds 2 and 1 (each within the scatter of the next).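

The arm carrying the sulfur does affect the result in this assay: the (4-carboxybenzyl)sulfanyl group gives a 6.1-fold lower number from compound 2 to compound 3 (0.79 log units; beyond the scatter) and a 7.5-fold lower number from compound 1 to compound 3 (0.88 log units; beyond the scatter), whereas the earlier change at this arm stayed within the scatter. This change makes two edits at once, as the oxygen leaves the sulfur and the carboxylic acid moves to another ring position, and the values cannot divide the effect between them. Nothing available explains why the number falls.

Still open, from the compounds shown here alone, is how much of the step belongs to each edit, which a 3-carboxybenzyl group on an oxygen-free sulfur would help to separate. Going by these compounds, it is also open whether a sulfone, with two oxygens on the sulfur, or an amide in place of the carboxylic acid would keep the lower number.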